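This account rests on a few compounds, and the source may have more. Where it says the series, first, only, none or still open, it means among the compounds named here.

Three related compounds have a number in a physicochemical assay for solubility, with a stated time of 24 h, tested at 30 mg/mL; a lower number here means a less soluble compound, a higher number a more soluble compound. Compound 1 (`CC(=O)N1CC(CC(=O)NO)(NS(=O)(=O)c2ccc(Cc3cc(C)nc4ccccc34)cc2)C1`) gives 1900000 nM, compound 2 (`CCc1cc(COc2ccc(S(=O)(=O)NC3(CC(=O)NO)CN(C(C)=O)C3)cc2)c2ccccc2n1`) gives 400000 nM, and compound 3 (`Cc1cc(COc2ccc(S(=O)(=O)NC(C)(C)CC(=O)NO)cc2)c2ccccc2n1`) gives 1600000 nM. Compound 3 therefore cannot be told apart from compound 1, as the gap between them lies within the usual scatter of repeated measurements, while compound 2 sits lower than compound 3 by a gap beyond that scatter.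

Compound 4 (`Cc1cc(COc2ccc(S(=O)(=O)NC3(C(=O)NO)CC3)cc2)c2ccccc2n1`) has not been measured yet. It differs from compound 3 in one place, on a sulfonamide nitrogen, where a group with one three-membered non-aromatic ring of carbon only takes the place of a group with no ring: a group of 7 heavy atoms (4 carbon, 1 nitrogen, 2 oxygen; one three-membered non-aromatic ring of carbon only) in place of a group of 8 heavy atoms (5 carbon, 1 nitrogen, 2 oxygen; no ring), on a sulfonamide nitrogen. Among the measured compounds shown here, no two measured compounds differ in just one place, so there is no direct precedent for this swap. For the measured compounds named here, the only guide is the spread of the measured compounds, which differ from one another in more than one place and still run only from compound 2 at 400000 nM to compound 1 at 1900000 nM. A slight drop is therefore expected, with the estimated 1.3-fold lower number from compound 3 to compound 4 (0.12 log units; within the scatter) staying within the scatter. For compound 4 the estimated value is 1200000 nM, with an expected range of 400000 nM to 3000000 nM.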

Compound 4, solubility: 46000000 nM
Compound 4: the middle estimate sits 38-fold (1.58 log units) below what was measured, and the stated range ends below it.
By their numbers in this assay, from the lowest: compound 2; then compounds 3 and 1 (each within the scatter of the next); then compound 4.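

In this assay, among the compounds shown here, the group on a sulfonamide nitrogen matters far more than the earlier compounds could suggest: a group of 7 heavy atoms with one three-membered non-aromatic ring of carbon only, in place of a group of 8 heavy atoms with no ring, gives a 29-fold higher number from compound 3 to compound 4 (1.46 log units; beyond the scatter) as a large step. For the compounds shown here, this is the first pair here that differs in one place, so it gives the first direct reading of this position. It also shows that a large step can come from a swap in which both groups have the same counts of hydrogen-bond donors and acceptors and neither has a net charge, and no measurement shown here bears on why the number rose so far.

The step changes the ring and the heavy-atom count together, so these compounds leave open which of the two goes with the rise. Going by these compounds, a cyclobutane ring or an open-chain group of 7 heavy atoms at the same place would help separate them, and it also remains open whether the same swap gives a similar step in compounds with a different core.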